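Nitro for Chloro on the Phenoxy Tail

This account rests on a few compounds, and the source may have more. Where it says the series, first, only, none or still open, it means among the compounds named here.

The two measured compounds share one core and differ only in the group carried on the chain that leaves the aromatic oxygen. Compound 1 `CC(C)=CCC/C(C)=C/COc1cc(=O)n(CCCO)c2c1CC(C/C=C(\C)CCC=C(C)C)C(C)(C)C2` gives 15.8% in a functional assay on PANC-1 cells (Homo sapiens) for inhibition, read by MTT assay, with a stated time of 24 h, tested at 10 uM; on this read-out higher numbers stand for more inhibition at the one concentration tested (going by the name of the read-out) and lower numbers for less inhibition. Compound 2 `CC(C)=CCC/C(C)=C/CC1Cc2c(OCCCOc3ccc(Cl)cc3)cc(=O)n(CCCO)c2CC1(C)C`, in which a 2-(4-chlorophenoxy)ethyl group replaces the 2,6-dimethylhepta-1,5-dien-1-yl group, gives 25.2% in this assay. The step of a number 9.4 percentage points higher from compound 1 to compound 2 (within the scatter) is within the scatter, so compound 2 stands highest of the two numbers only nominally, with compound 1 within the scatter of it.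

Compound 3 `CC(C)=CCC/C(C)=C/CC1Cc2c(OCCCOc3ccc([N+](=O)[O-])cc3)cc(=O)n(CCCO)c2CC1(C)C` carries the change (nitro in place of chloro on an aromatic carbon). For the measured compounds named here, no measured step touches the same position; the only step known, a number 9.4 percentage points higher from compound 1 to compound 2 (within the scatter), exchanged the whole tail and still moved the read-out by less than the scatter. With so small a response to a far larger change, the expected step of a number 0.2 percentage points lower from compound 2 to compound 3 (within the scatter) is one of no size beyond the scatter, in either direction. Compound 3 is therefore estimated at 25% in this assay, with a range from 10% to 42%.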

Compound 3, a percentage reported as inhibition, at one concentration (the size of the read-out at that concentration, not a potency): 65.1%
For compound 3 the middle estimate is 40.1 percentage points below the measured one; the measured number lies above the stated range.
By their numbers in this assay, from the lowest: compounds 1 and 2 (each within the scatter of the next); then compound 3.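

In this assay the aromatic carbon carrying chloro in compound 2 proves to be a sensitive place: nitro in place of chloro gives a number 39.9 percentage points higher from compound 2 to compound 3 (beyond the scatter). The exchange of the whole tail between compound 1 and compound 2 did not do this. Set against the 2,6-dimethylhepta-1,5-dien-1-yl group of compound 1, the 2-(4-nitrophenoxy)ethyl group gives a number 49.3 percentage points higher from compound 1 to compound 3 (beyond the scatter) and this shows that the phenoxy tail alone does not set the read-out; compound 2 also carries a phenoxy tail and lies within the scatter of compound 1. Nothing measured here bears on why nitro stands apart from chloro at this place.

The compounds shown hold only chloro and nitro at this place, and they leave open whether the rise belongs to nitro alone or would also appear with a nitrile, an amine or a carboxylic acid there. They also leave open whether the same exchange would hold with a longer chain between the aromatic oxygen and the phenoxy group.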